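Thiophene in Place of Methoxyphenyl on a Shared Core

The compounds below may be only part of what the source reports. "The series", "measured", "known", "first", "only" and "open" are said of these compounds alone.

Compound 2 `COc1cccc(/C=C/C(=O)Nc2ccc3ncnc(Nc4cccc(Cl)c4)c3c2)c1` gives 2.58 ug/mL in a functional assay on A549 cells (Homo sapiens) for antiproliferative activity, read by MTT assay, with a stated time of 48 h (on this read-out higher numbers stand for weaker inhibition and lower numbers for stronger inhibition), the lowest of the two numbers recorded; compound 1 `O=C(/C=C/c1cccs1)Nc1ccc2ncnc(Nc3cccc(Br)c3)c2c1`, which carries a thiophen-2-yl group, gives 4.66 ug/mL, a difference that lies within the scatter. Compound 3 `O=C(/C=C/c1cccs1)Nc1ccc2ncnc(Nc3cccc(Cl)c3)c2c1` is the unmeasured partner of compound 2, differing by thiophen-2-yl in place of 3-methoxyphenyl on a double-bonded chain carbon bound to a double-bonded chain carbon. Among the measured compounds shown here, no measured pair tests this change directly, so no step beyond the scatter is expected in either direction, in line with what compound 1 shows at 4.66 ug/mL. Compound 3 is therefore estimated at 3.8 ug/mL, between 1.5 ug/mL and 9.5 ug/mL, a step of a 1.5-fold higher number from compound 2 to compound 3 (0.17 log units; within the scatter) that is expected to stay within the scatter.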

Compound 3, half-maximal inhibitory concentration: 9.23 ug/mL
Beside the measured number, compound 3's estimate is 2.4-fold (0.39 log units) below it, within the range that was stated.
By their numbers in this assay, from the lowest: compounds 2, 1 and 3 (each within the scatter of the next, the first and the last beyond it).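

In this assay, among the compounds shown here, thiophen-2-yl in place of 3-methoxyphenyl on a double-bonded chain carbon bound to a double-bonded chain carbon gives a 3.6-fold higher number from compound 2 to compound 3 (0.55 log units; beyond the scatter), so this position responds to the change of group, which the earlier compounds could not show. Chloro in place of bromo on an aromatic carbon gives a 2.0-fold higher number from compound 1 to compound 3 (0.30 log units; within the scatter), which stays within the scatter. No supporting data bear on the origin of the step. Going by these compounds, whether an unsubstituted phenyl or a pyridin-3-yl at this place would read like compound 2 or like compound 3 remains open. So does whether the step holds with bromo in place of chloro.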